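The compounds below may be only part of what the source reports. "The series", "measured", "known", "first", "only" and "open" are said of these compounds alone.

Measured in a functional assay on HCT-116 cells (Homo sapiens) for inhibition, read by sulforhodamine B assay, with a stated time of 48 h, tested at 50 uM; a higher number here means more inhibition of growth at the concentration tested, a lower number less inhibition of growth:
compound 1 `COc1cc(/C=C/C(=O)/C=C/c2cccc3ccccc23)ccc1OCc1cn(CCCOc2cc(=O)oc3ccccc23)nn1` gives 66%
compound 2 `COc1cc(/C=C/C(=O)/C=C/c2ccco2)ccc1OCc1cn(CCCOc2cc(=O)oc3ccccc23)nn1` gives 51%
compound 3 `COc1cc(/C=C/C(=O)/C=C/c2cccc3ccccc23)ccc1OCc1cn(CCCCOc2cc(=O)oc3ccccc23)nn1` gives 56%

Compound 4 `COc1cc(/C=C/C(=O)/C=C/c2ccco2)ccc1OCc1cn(CCCCOc2cc(=O)oc3ccccc23)nn1` has not been measured. It differs from compound 3 in one place, (furan-2-yl in place of naphthalen-1-yl on a double-bonded chain carbon bound to a double-bonded chain carbon). The same change separates compound 2 from compound 1, (furan-2-yl in place of naphthalen-1-yl on a double-bonded chain carbon bound to a double-bonded chain carbon), and in this assay it gave a number 15 percentage points lower from compound 1 to compound 2 (beyond the scatter). The difference between the cores of compound 1 and compound 3 is not broken down here; the values of compound 3 and compound 1 lie within the scatter of each other, as do those of compound 3 and compound 2.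

For the measured compounds named here, for compound 4 a step of similar size is expected, a number 15 percentage points lower from compound 3 to compound 4 (beyond the scatter), because a number 15 percentage points lower from compound 1 to compound 2 (beyond the scatter) is the only measured instance of this change and the two cores sit close in value. Compound 4 is therefore estimated at 41% in this assay, expected between 28% and 54%.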

Compound 4, percent growth inhibition at one concentration: 47%
The estimate for compound 4 lay 6 percentage points below the measured number; the range from low to high includes it.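

In this assay furan-2-yl in place of naphthalen-1-yl gives a number 9 percentage points lower from compound 3 to compound 4 (within the scatter) on the core of compound 3. Set beside the earlier step, the two cannot be told apart: the same change on two cores in this assay, a number 15 percentage points lower (beyond the scatter) from compound 1 to compound 2 and a number 9 percentage points lower (within the scatter) from compound 3 to compound 4, 6 percentage points apart, within the scatter of two such steps. This is consistent with the change carrying from one core to the other in this pair of cores, but two instances do not fix a step size, and the later step alone does not show a real loss on the core of compound 3.

Open, on these data alone, is how an amine or a carboxylic acid would fare on a double-bonded chain carbon bound to a double-bonded chain carbon. Also open, as far as these compounds go, is whether the step holds on a core with a longer chain.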